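Iodo in place of methyl on compound 1

The compounds below may be only part of what the source reports. "The series", "measured", "known", "first", "only" and "open" are said of these compounds alone.

Values in an ADME assay on HeLa cells (Homo sapiens) for cytotoxicity, read by resazurin assay, with a stated time of 2 days; on this read-out lower numbers stand for stronger inhibition and higher numbers for weaker inhibition:
- compound 1 `Cc1cccc(/C=C/c2ncc([N+](=O)[O-])n2C)c1` gives 30900 nM
- compound 2 `Cc1cc(C)c(/C=C/c2ncc([N+](=O)[O-])n2C)c(C)c1` gives 11000 nM
- compound 3 `Cn1c([N+](=O)[O-])cnc1/C=C/c1ccc(Cl)cc1Cl` gives > 100000 nM, a limit of the assay and not a number

Compound 1 at 30900 nM has the higher of the two numbers, and compound 2 at 11000 nM lies lower, beyond the scatter. Compound 4 `Cn1c([N+](=O)[O-])cnc1/C=C/c1cccc(I)c1` is not yet measured. It carries iodo in place of methyl on an aromatic carbon, meta to a large group (iodo in place of methyl on an aromatic carbon). Within the data shown here, no measured pair isolates this change. In this assay no step beyond the scatter is expected, and any drift is expected toward lower numbers. This expectation starts from compound 1 at 30900 nM and leans toward compound 2 at 11000 nM. The expected change is a 1.3-fold lower number from compound 1 to compound 4 (0.11 log units; within the scatter). For compound 4 the estimated value is 24000 nM, with an expected range of 8000 nM to 75000 nM.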

Compound 4, half-maximal inhibitory concentration: 31600 nM
The estimate for compound 4 lay 1.3-fold (0.12 log units) below the measured number, and the stated range covers the measured number.
By their numbers in this assay, from the lowest: compound 2; then compounds 1 and 4 (each within the scatter of the next). At a limit, above all of these: compound 3.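

In this assay, among these compounds, iodo in place of methyl on an aromatic carbon, meta to a large group, gives a 1.0-fold higher number from compound 1 to compound 4 (0.01 log units; within the scatter) and provides the first single-place step. At this position, the read-out therefore does not separate these two groups, each counted as 1 heavy atom. The data shown offer no cause for this result.

From the compounds shown here alone, whether an amine or a carboxylic acid at this position would shift the number remains open. Also open, going by these compounds, is whether the same exchange would read alike elsewhere on the ring.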